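The compounds below may be only part of what the source reports. "The series", "measured", "known", "first", "only" and "open" are said of these compounds alone.

- compound 1 `CNc1nc(NC(C#N)(C2CC2)C2CC2)nc(-n2cncn2)n1`: 3.7 mL/min/kg
- compound 2 `CCCC(C#N)(CC)Nc1nc(NC)nc(-n2cncn2)n1`: 29 mL/min/kg

In an ADME assay on microsomes from liver (Rattus norvegicus) for metabolic stability (on this read-out higher numbers stand for fast clearance and lower numbers for slow clearance), compound 2 has the higher of the two numbers, and its gap to compound 1 lies beyond the usual scatter. Compound 3 `CCCC(C#N)(CCC)Nc1nc(NC)nc(-n2cncn2)n1` differs from compound 2 by methyl in place of hydrogen on a saturated chain carbon, three bonds along the chain from a nitrogen on an aromatic ring and a triple-bonded carbon: methyl in place of hydrogen on a saturated chain carbon, which turns ethyl to propyl. Among the compounds with values here, no measured pair shows this change, so the starting point is compound 2 at 29 mL/min/kg. A small upward move, within the scatter, is expected, and the estimated step of a 1.4-fold higher number from compound 2 to compound 3 (0.14 log units; within the scatter) reflects that. For compound 3, the expected clearance is 40 mL/min/kg, with an estimated range of 20 mL/min/kg to 80 mL/min/kg.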

Compound 3, clearance: 32 mL/min/kg
For compound 3 the middle estimate is 1.3-fold (0.10 log units) above the measured one; the measured number falls inside the stated range.
By their numbers in this assay, from the lowest: compound 1; then compounds 2 and 3 (each within the scatter of the next).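

In this assay, lengthening ethyl to propyl at this position gives a 1.1-fold higher number from compound 2 to compound 3 (0.04 log units; within the scatter) and so leaves no readable shift in clearance. Within the data shown here, this is the first step measured at this place, since compound 1 differs from compound 2 and compound 3 in more than one place and could not show the effect of this single change. No measurement available here offers an explanation for the result. Going by these compounds, it remains open whether a longer chain such as butyl at this place would also leave clearance unshifted. An amine or a hydroxyl group on this chain is also an open case.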